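The source may report more compounds than this note shows. Statements on the series, on what has been measured and on what is new or still open speak of the compounds shown alone.

In an ADME assay on HeLa cells (Homo sapiens) for cytotoxicity, read by ATP content, with a stated time of 3 days (a lower number here means that less compound is tolerated, a higher number that more compound is tolerated), compound 1, with the structure `N#CCCCn1c(Cn2c(=O)n(-c3ccc(C(=O)NC4CC4)cc3)c3ccncc32)cc2cc(Cl)ccc21`, gives > 50000 nM, which is a limit of the assay rather than a measured number. Compound 2, with the structure `O=c1n(Cc2nc3cnccc3n2CCCCO)c2cnccc2n1C1CC1`, gives > 100000 nM in this assay, again a limit. The two values shown are thus both limits, one sitting at the limit of > 100000 nM in this assay, at which 1 of the 2 values shown sits, and the other at the limit of > 50000 nM in this assay, at which 1 of the 2 values shown sits, so compound 1 cannot be placed on a scale against any measured number; it stands only as a compound tolerated up to its limit. The unmeasured compound 3 has the structure `N#CCCCn1c(Cn2c(=O)n(C3CC3)c3ccncc32)cc2cc(Cl)ccc21`. It differs from compound 1 in one place: cyclopropyl in place of 4-(cyclopropylcarbamoyl)phenyl on an aromatic nitrogen. Among the compounds with values here, no step between measured compounds is available, so nothing measured here tells how this change shifts the tolerated concentration. Since compound 1 already sits at a limit, the expected step in this assay from compound 1 to compound 3 is a step that the limit leaves unreadable from compound 1 to compound 3, no more than the scatter. Compound 3 is therefore expected to give about 60000 nM in this assay, within a range from 30000 nM to 150000 nM, and most likely again to be reported only as a limit.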

Compound 3, half-maximal cytotoxic concentration: > 50000 nM
Compound 3 was reported as a limit (the forecaster's own chance of this, stated with the estimate: 80%); the middle value lies beyond the limit too.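

Compound 1 and compound 3 both stand only at a limit, and no step from compound 1 to compound 3 can be read in this assay: the limit of > 50000 nM in this assay, at which 2 of the 3 values shown sit.

The compounds shown leave open whether cyclopropyl and 4-(cyclopropylcarbamoyl)phenyl on that aromatic nitrogen differ in the concentration tolerated, and at what concentration either compound would become cytotoxic.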